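Trifluoromethyl for methoxy on the benzyl ring of compound 2

The source may report more compounds than this note shows. Statements on the series, on what has been measured and on what is new or still open speak of the compounds shown alone.

Measured compounds:
- compound 1, `Cc1[nH]n(-c2nc3c(C)cccc3[nH]2)c(=O)c1Cc1ccccc1`, 5900 nM
- compound 2, `COc1ccc(Cc2c(C)[nH]n(-c3nc4ccccc4[nH]3)c2=O)cc1`, 630 nM
- compound 3, `Cc1[nH]n(-c2nc3cc(C(F)(F)F)ccc3[nH]2)c(=O)c1Cc1ccccc1`, 610 nM

Of the compounds shown here, three sharing one core have been measured in an assay on isolated protein for inhibition of alpha-ketoglutarate-dependent dioxygenase alkB homolog 3 (Homo sapiens), read by polymerase chain reaction, with a stated time of 1 h; a lower number here means a stronger inhibitor, a higher number a weaker inhibitor. Compound 1 gives 5900 nM, compound 2 gives 630 nM and compound 3 gives 610 nM. Compound 2 stands second highest of the three numbers; compound 3 sits within the scatter of it, while compound 1 lies a clear step higher, beyond the scatter.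

The unmeasured compound 4, `Cc1[nH]n(-c2nc3ccccc3[nH]2)c(=O)c1Cc1ccc(C(F)(F)F)cc1`, differs from compound 2 in one place: trifluoromethyl in place of methoxy on an aromatic carbon, on an aromatic carbon of a six-membered aromatic ring of carbon only, para to a large group. For the measured compounds named here, no measured pair shows this same exchange, so the size of the step cannot be read from a matching precedent. Compound 3 carries a trifluoromethyl elsewhere on the core and gives a number close to compound 2, which offers no pointer either way.

The step of a 1.3-fold higher number from compound 2 to compound 4 (0.13 log units; within the scatter) is therefore expected to be small, most likely inside the usual scatter, with a slight lean toward a higher number. Compound 4 is estimated at 850 nM in this assay, with a range from 250 nM to 2800 nM.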

Compound 4, half-maximal inhibitory concentration: 550 nM
Compound 4: the middle estimate sits 1.5-fold (0.19 log units) above what was measured; the measured number falls inside the stated range.
By their numbers in this assay, from the lowest: compounds 4, 3 and 2 (each within the scatter of the next); then compound 1.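

In this assay, trifluoromethyl in place of methoxy on an aromatic carbon, para to a large group, gives a 1.1-fold lower number from compound 2 to compound 4 (0.06 log units; within the scatter), so this pair does not separate the two groups at this position. For the compounds shown here, it is the first step between measured compounds that differ in one place, and it shows that, in this pair, the hydrogen-bond acceptor counted on methoxy can leave and the larger trifluoromethyl can enter without a change beyond the usual scatter. Nothing available explains why the two groups give such similar numbers.

The compounds shown leave open what either group contributes, as they offer no direct comparison with a plain hydrogen at this place on the otherwise identical compound. As far as these compounds go, it also remains open whether this tolerance extends to an amine, a carboxylic acid or a longer alkyl chain at the same aromatic carbon, or whether such a group would move the number beyond the scatter.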